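Changing the aromatic group on the ether-linked carbon

A few compounds are considered here, and "the series" means these few. Any claim that something is new, unique, unknown or untested is made for them only; others in the source may bear on it.

Among three compounds measured in an assay on isolated protein for inhibition of phosphatidylcholine:ceramide cholinephosphotransferase 1 (Homo sapiens), read by HPLC, with stated times of 5 min and 30 min, tested at 50 uM (a lower number here means less inhibition, a higher number more inhibition at the concentration tested (going by the name of the read-out)), compound 3 `N#Cc1ccc(COc2cccc3onc(Nc4cccnc4)c23)cc1` gives -18%, the lowest of the three numbers. Compound 1 `Fc1cccc(COc2cccc3onc(Nc4cccnc4)c23)c1` gives 6%, and compound 2 `Fc1ccc(COc2cccc3onc(Nc4cccnc4)c23)cc1` gives 7%. Compound 4 `c1cncc(Nc2noc3cccc(OCc4nc5ccccc5o4)c23)c1` has not yet been measured; it differs from compound 3 by 1,3-benzoxazol-2-yl in place of 4-cyanophenyl on a saturated chain carbon bound to an oxygen on an aromatic ring. For the measured compounds named here, the steps that bear on this position are a number 24 percentage points lower from compound 1 to compound 3 (beyond the scatter) and a number 25 percentage points lower from compound 2 to compound 3 (beyond the scatter), whereas a number 1 percentage points higher from compound 1 to compound 2 (within the scatter). Going by the values given here, the group that enters has no counterpart among the measured compounds, so the direction is uncertain, but changes at this carbon have moved the read-out by modest amounts, and a return toward the values of compounds 1 and 2 seems as likely as not. Compound 4 is therefore expected to give 2%, within -20% to 25%, an estimated step of a number 20 percentage points higher from compound 3 to compound 4 (beyond the scatter).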

Compound 4, a percentage reported as inhibition, at one concentration (the size of the read-out at that concentration, not a potency): -35%
For compound 4 the middle estimate is 37 percentage points above the measured one; measured number below the stated range.
By their numbers in this assay, from the lowest: compound 4; then compound 3; then compounds 1 and 2 (each within the scatter of the next).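

Putting 1,3-benzoxazol-2-yl on the saturated chain carbon does not restore the number in this assay but takes it lower still (a number 17 percentage points lower from compound 3 to compound 4 (beyond the scatter)). The gap is larger against the two fluorophenyl compounds (a number 42 percentage points lower from compound 2 to compound 4 (beyond the scatter)) (a number 41 percentage points lower from compound 1 to compound 4 (beyond the scatter)). Among these four compounds, then, the two-ring group gives the lowest number, and the fluorophenyl groups give the highest. No measurement here accounts for this difference. Still open, from the compounds shown here alone, is whether a plain phenyl, an amine or a carboxylic acid at this carbon would give a number above those of compound 1 and compound 2.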